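From 2-hydroxy-2-methylpentyl to oxan-3-yl on a carbonyl carbon

A few compounds are considered here, and "the series" means these few. Any claim that something is new, unique, unknown or untested is made for them only; others in the source may bear on it.

In a functional assay on HeLa cells (Homo sapiens) for cytotoxicity, read by MTT assay (on this read-out lower numbers stand for stronger inhibition and higher numbers for weaker inhibition), three compounds sharing one core have been measured. Compound 1 (`CC(C)=CC[C@@H](OC(=O)CCO)C1=CC(=O)c2c(O)ccc(O)c2C1=O`) gives 67600 nM, compound 2 (`CC[C@@](C)(O)CC(=O)O[C@H](CC=C(C)C)C1=CC(=O)c2c(O)ccc(O)c2C1=O`) gives 17900 nM, and compound 3 (`CCCC(C)(O)CC(=O)O[C@H](CC=C(C)C)C1=CC(=O)c2c(O)ccc(O)c2C1=O`) gives 72000 nM. Compound 3 stands at the high end of this small set, alongside compound 1. The step of a 1.1-fold higher number from compound 1 to compound 3 (0.03 log units; within the scatter) stays within the scatter, whereas the step of a 4.0-fold higher number from compound 2 to compound 3 (0.60 log units; beyond the scatter) goes beyond it.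

Compound 4 (`CC(C)=CC[C@@H](OC(=O)C1CCCOC1)C1=CC(=O)c2c(O)ccc(O)c2C1=O`) carries oxan-3-yl in place of 2-hydroxy-2-methylpentyl on a carbonyl carbon. The measured steps all exchange one open chain for another, and none places a ring here, so they offer only a loose guide. Even so, the largest of them are modest, namely a 3.8-fold lower number from compound 1 to compound 2 (0.58 log units; beyond the scatter) and a 4.0-fold higher number from compound 2 to compound 3 (0.60 log units; beyond the scatter), so no large shift is expected in this assay. The expected step is a 1.6-fold lower number from compound 3 to compound 4 (0.20 log units; within the scatter), which would not go beyond the scatter. For compound 4 the estimated value is 45000 nM, with an expected range of 14000 nM to 110000 nM.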

Compound 4, half-maximal inhibitory concentration: 60500 nM
The estimate for compound 4 lay 1.3-fold (0.13 log units) below the measured number, and the stated range covers the measured number.
By their numbers in this assay, from the lowest: compound 2; then compounds 4, 1 and 3 (each within the scatter of the next).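

The oxan-3-yl ring, the first ring at this place and one with 0 hydrogen-bond donors, leaves the number within the scatter of two open chains that each carry a hydroxyl group, in this assay (a 1.2-fold lower number from compound 3 to compound 4 (0.08 log units; within the scatter); a 1.1-fold lower number from compound 1 to compound 4 (0.05 log units; within the scatter)). So among these compounds, the ring and the loss of the hydroxyl group do not separate compound 4 from compounds 1 and 3, while compound 2, with its 2-hydroxy-2-methylbutyl group, remains the exception (a 3.4-fold higher number from compound 2 to compound 4 (0.53 log units; beyond the scatter)). Nothing available explains why compound 2 alone stands apart.

From the compounds shown here alone, whether a basic amine such as a piperidine ring, or a carboxylic acid, on this carbonyl carbon would shift the number remains open. So does whether any other ring here could match compound 2, since oxan-3-yl is the only ring shown.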